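This account rests on a few compounds, and the source may have more. Where it says the series, first, only, none or still open, it means among the compounds named here.

For the measured compounds named here, compound 1, `Cc1csc2cc([C@H](C)Nc3ncnc(N)c3C#N)c(-c3cccc(CN(C)CCCCN(C)Cc4ccccc4)c3)c(=O)n12`, is one of two compounds measured in an ADME assay on the whole organism (lung, Rattus norvegicus) for metabolic stability, read by LC-MS; on this read-out lower numbers stand for a shorter-lived compound and higher numbers for a longer-lived compound; in this assay compound 1 gives 17.6 h, while compound 2, `Cc1csc2cc([C@H](C)Nc3ncnc(N)c3C#N)c(-c3cccc(CN4CCC(CN(C)CC(C)C)CC4)c3)c(=O)n12`, gives 12 h, and the two values lie within the usual scatter of each other. Compound 3, `Cc1csc2cc([C@H](C)Nc3ncnc(N)c3C#N)c(-c3cccc(CN(C)CCCN(C)Cc4ccc(Cl)cc4)c3)c(=O)n12`, is not yet measured. Compound 3 differs from compound 1 by (4-chlorobenzyl)(methyl)amino in place of (benzyl(methyl)amino)methyl on a saturated chain carbon, three bonds along the chain from an amine nitrogen. Going by the values given here, no step between measured compounds covers this change, so only a small step, in no set direction and not beyond the scatter, is expected in this assay. Compound 3 is estimated at 15 h, with a range from 7 h to 32 h. The step from compound 1 to compound 3 is expected to be a 1.2-fold lower number from compound 1 to compound 3 (0.07 log units; within the scatter).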

Compound 3, half-life in the lung assay: 13 h
Compound 3: the middle estimate sits 1.2-fold (0.06 log units) above what was measured, and the stated range covers the measured number.
By their numbers in the lung assay, from the lowest: compounds 2, 3 and 1 (each within the scatter of the next).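

In the lung assay, replacing (benzyl(methyl)amino)methyl with (4-chlorobenzyl)(methyl)amino on this saturated chain carbon gives a 1.4-fold lower number from compound 1 to compound 3 (0.13 log units; within the scatter), so this change leaves the two half-lives within the scatter of each other. In a physicochemical assay for lipophilicity (a lower number here means a more polar compound, a higher number a more lipophilic compound), compound 1 gives 2.2 and compound 3 gives 3.2, which separates the same two compounds clearly: the measured distribution coefficient of compound 1, 2.2, and of compound 3, 3.2, a number 1.00 log units higher (beyond the scatter)

The change goes from a propyl to an ethyl chain and brings in chlorine at once, so the compounds shown cannot separate these two parts. Going by these compounds, whether a fluorine or a methoxy group in place of the chlorine, or a longer chain, would also stay within the scatter in the lung assay remains open.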